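A few compounds are considered here, and "the series" means these few. Any claim that something is new, unique, unknown or untested is made for them only; others in the source may bear on it.

For the measured compounds named here, compound 3 `FC(F)(F)c1ccccc1Nc1nc(-c2ccncc2)cs1` is measured in a functional assay on RCC4 cells (Homo sapiens) for inhibition, read by XTT assay, with a stated time of 4 days (on this read-out higher numbers stand for weaker inhibition and lower numbers for stronger inhibition), where compound 3 gives 40700 nM; this is the only number among its entries, two further entries giving no single number. Compound 1 `Cc1cccc(Nc2nc(-c3ccncc3C#CCCCO)cs2)c1` gives 6300 nM; 1120 nM (2 entries) in this assay, a spread shown by the several entries of compound 1 in this assay, 6300 nM; 1120 nM (2 entries), and compound 2 `Cc1cccc(Nc2nc(-c3ccncc3-c3ccncc3)cs2)c1` gives 13800 nM; 13800 nM (2 entries). Compound 4 `Clc1ccccc1Nc1nc(-c2ccncc2)cs1` has not yet been measured in this assay. It differs from compound 3 by chloro in place of trifluoromethyl on an aromatic carbon. No step between measured compounds is shown, so the step from compound 3 to compound 4 is expected to be small, with no direction beyond the usual scatter. On that basis compound 4 is estimated to give 30000 nM, within 8000 nM to 120000 nM, a step of a 1.4-fold lower number from compound 3 to compound 4 (0.13 log units; within the scatter).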

Compound 4, half-maximal inhibitory concentration: 28200 nM
For compound 4 the middle estimate is 1.1-fold (0.03 log units) above the measured one; measured number inside the range.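

Chloro in place of trifluoromethyl on an aromatic carbon, ortho to a large group, is the first single-place step among these compounds, and it gives a 1.4-fold lower number from compound 3 to compound 4 (0.16 log units; within the scatter). The two groups therefore cannot be told apart at this position in this assay. A small step here deserves caution, since repeated entries in this assay can differ widely: the several entries of compound 1 in this assay, 6300 nM; 1120 nM (2 entries)

The compounds shown leave open whether an amine or a carboxylic acid at this position would move the number beyond the scatter. They also leave open whether the same exchange would behave alike on the core of compound 1.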